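The source may hold more compounds than are shown below. What is called first, only, known or untested is meant among the compounds shown, and "the series" means these compounds.

Measured so far, in a functional assay on BGC-823 cells (Homo sapiens) for antiproliferative activity, read by MTT assay, tested at 1 uM; on this read-out lower numbers stand for a weaker effect and higher numbers for a stronger effect at the one concentration tested:

- compound 1 `COc1cc(C(=O)N/N=C/c2ccc(F)c(F)c2)cc(OC)c1OC` gives 33.1%
- compound 2 `COc1ccc(C2OC(c3cc(OC)c(OC)c(OC)c3)=NN2C(C)=O)c(OC)c1` gives 6.3%

Of these two numbers, compound 2 has the lower one. Compound 1 stands well above it, by a gap that is beyond the usual scatter of this kind of measurement, so the two compounds are truly told apart by this assay, although their shared core is not the same and no single change links them.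

Compound 3 `COc1cc(C2=NN(C(C)=O)C(c3cccc(C(F)(F)F)c3)O2)cc(OC)c1OC` is not yet measured. It differs from compound 2 in one place: 3-(trifluoromethyl)phenyl in place of 2,4-dimethoxyphenyl on a saturated ring carbon. For the measured compounds named here, no pair of measured compounds differing in one place is available, so there is no measured step to lean on for this kind of swap.

Given the lack of any measured step, the expectation for compound 3 is a modest rise in this assay rather than a large one. The step from compound 2 to compound 3 is expected to be a number 5.7 percentage points higher from compound 2 to compound 3 (within the scatter), which may not exceed the scatter. Compound 3 is therefore estimated at 12%, with a range from 0% to 30%.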

Compound 3, a percentage reported as inhibition, at one concentration (the size of the read-out at that concentration, not a potency): 27.9%
Beside the measured number, compound 3's estimate is 15.9 percentage points below it; measured number inside the range.
By their numbers in this assay, from the lowest: compound 2; then compounds 3 and 1 (each within the scatter of the next).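

In this assay, the group on the saturated ring carbon, next to the ring nitrogen and the ring oxygen, now has a measured effect: 3-(trifluoromethyl)phenyl in place of 2,4-dimethoxyphenyl gives a number 21.6 percentage points higher from compound 2 to compound 3 (beyond the scatter). The earlier compounds shown here could not show this, since they differ in more than one place and offered no single change to read. This swap keeps the heavy-atom count and the six-membered aromatic ring of carbon, yet the read-out still separates the two groups, so this position responds to what the ring carries, and nothing available here explains why.

One swap cannot tell whether the step comes from losing the two methoxy groups, from gaining the trifluoromethyl group, or from both, and a plain phenyl at this carbon would be a natural reference point for separating those options. As far as these compounds go, it also remains open how a phenyl ring carrying an amine or a carboxylic acid would read here, and whether the same swap would have a similar effect on a different core.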